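A hydroxymethyl to methyl step at the assay limit

A few compounds are considered here, and "the series" means these few. Any claim that something is new, unique, unknown or untested is made for them only; others in the source may bear on it.

Measured in a functional assay on HeLa cells (Homo sapiens) for cytotoxicity, read by MTT assay; a higher number here means a weaker inhibitor, a lower number a stronger inhibitor:
- compound 1 `CC(=O)O[C@@H]1C[C@@H](OC(C)=O)C(C)(C)[C@H](O)[C@H]2O[C@@]3(C[C@H](C)[C@H](OC(=O)c4ccccc4)[C@@H]3/C=C/1C)[C@@H](OC(C)=O)[C@H]2C`: > 10000 nM (a limit)
- compound 2 `CC(=O)O[C@H]1[C@@H](C)/C=C/C(C)(C)[C@H](O)C[C@@H](O)/C(C)=C/[C@H]2[C@@H](OC(=O)c3ccccc3)[C@@H](C)C[C@@]21O`: > 10000 nM (a limit)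
- compound 3 `CC(=O)O[C@@H]1C[C@@H](OC(C)=O)C(C)(C)/C=C/[C@H](C)[C@H](OC(C)=O)[C@@]2(O)C[C@H](C)[C@H](OC(=O)c3ccccc3)[C@@H]2/C=C/1CO`: > 10000 nM (a limit)

In this assay compound 3 gives only a limit, > 10000 nM, and no number. Compound 1 and compound 2 end at a limit as well, so the series offers no measured number to compare.

Compound 4 `CC(=O)O[C@@H]1C[C@@H](OC(C)=O)C(C)(C)/C=C/[C@H](C)[C@H](OC(C)=O)[C@@]2(O)C[C@H](C)[C@H](OC(=O)c3ccccc3)[C@@H]2/C=C/1C` differs from compound 3 by one change, (hydrogen in place of hydroxy on a saturated chain carbon bound to a double-bonded ring carbon). This puts hydrogen in place of hydroxy on a saturated chain carbon bound to a double-bonded ring carbon, so that hydroxymethyl becomes methyl. Among the measured compounds shown here, no measured pair shows what this change does on its own.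

For the measured compounds named here, a clear gain in potency is not expected because the limit of > 10000 nM in this assay, at which 3 of the 3 values shown sit, applies to every compound tested so far. The estimate therefore expects a step that the limit leaves unreadable from compound 3 to compound 4, with no change beyond the scatter in either direction. For compound 4 the estimated value is 15000 nM within an expected range from 5000 nM to 50000 nM and most likely only a limit will be reported.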

Compound 4, half-maximal inhibitory concentration: 3100 nM
The estimate for compound 4 lay 4.8-fold (0.68 log units) above the measured number, outside the stated range (below it).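

In this assay, the change from hydroxymethyl to methyl on a saturated chain carbon bound to a double-bonded ring carbon gives an at least 3.2-fold lower number from compound 3 to compound 4 (0.50 log units; beyond the scatter). Among the compounds shown here, compound 4 is the only one of the four compounds with a number rather than a limit, which shows that this single place can move the result beyond the scatter on this core. The true size of the step stays unknown, since it is bounded on one side only: the limit of > 10000 nM in this assay, at which 3 of the 4 values shown sit.

The compounds shown leave open how far compound 3 really lies from compound 4, and whether the same change would act alike on any other core. They also leave open what an aminomethyl group, a carboxylic acid or an ethyl group at this place would do to the number.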